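A Heteroaryl Swap at the Cytotoxicity Limit

The compounds below may be only part of what the source reports. "The series", "measured", "known", "first", "only" and "open" are said of these compounds alone.

compound 1 `CCCCNc1nc(N)nc2ccn(CCCc3ccccc3)c12`: > 24000 nM
compound 2 `CCCCNc1nc(N)nc2ccn(Cc3nccs3)c12`: > 24000 nM
compound 3 `Cc1nc(CNc2nc(N)nc3ccn(Cc4ccccn4)c23)cs1`: > 24000 nM

Of the compounds shown here, three have been measured in an ADME assay on HEK293 cells (Homo sapiens) for cytotoxicity, read by ATP content, with a stated time of 6 h; on this read-out higher numbers stand for lower toxicity in this test and lower numbers for higher toxicity in this test. Compound 1 reaches only the limit of this assay, > 24000 nM. Compound 2 likewise gives only a limit, > 24000 nM. Compound 3 also stops at a limit, > 24000 nM. Going by the values given here, the only step between neighbouring measured compounds, a step that the two limits leave unreadable from compound 1 to compound 2, sits between two limits and gives no readable size. Compound 3 therefore stands where every measured value sits, at the limit of > 24000 nM in this assay, at which 3 of the 3 values shown sit, with no number to separate it from its neighbours.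

Compound 4 `CC(C)c1cc(CNc2nc(N)nc3ccn(Cc4ccccn4)c23)no1` differs from compound 3 by 5-isopropyl-1,2-oxazol-3-yl in place of 2-methyl-1,3-thiazol-4-yl on a saturated chain carbon bound to a nitrogen on an aromatic ring. Among the compounds with values here, no measured step bears on this change, and the one step that exists between measured compounds is unreadable. With nothing to point either way, no step beyond the scatter is expected, and the estimated step that the limit leaves unreadable from compound 3 to compound 4 is essentially none. Compound 4 is expected at 30000 nM, within 15000 nM to 60000 nM, and most likely this assay will again report only a limit for compound 4.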

Compound 4, half-maximal cytotoxic concentration: > 24000 nM
Compound 4: only a limit was reported; the forecaster's own chance of this, stated with the estimate: 85%; the middle value does not contradict the limit.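

Going by these compounds alone, compound 3 and compound 4 both give only a limit in this assay, so no step between them can be read, and the values shown sit together at one point: the limit of > 24000 nM in this assay, at which 4 of the 4 values shown sit. The compounds shown leave open whether 5-isopropyl-1,2-oxazol-3-yl in place of 2-methyl-1,3-thiazol-4-yl, or any other change among them, alters the half-maximal cytotoxic concentration at all.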